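Swapping the Aryl Group on the Ring Nitrogen

The compounds below may be only part of what the source reports. "The series", "measured", "known", "first", "only" and "open" are said of these compounds alone.

Compound 1 `CCCc1nc(-c2ccccc2)c(CNCCN2CCN(c3ccccc3F)CC2)o1`: 46.5%
Compound 2 `CCCc1nc(-c2ccccc2)c(CNCCN2CCN(c3ccccc3Cl)CC2)o1`: 60.1%
Compound 3 `CCCc1nc(-c2ccccc2)c(CNCCN2CCN(c3ccc(F)cc3)CC2)o1`: 54.1%

In an assay on HEK293 cells for inhibition of Voltage-dependent T-type calcium channel subunit alpha-1G (Homo sapiens), read by fluorescence, tested at 10 uM (on this read-out lower numbers stand for less inhibition and higher numbers for more inhibition at the one concentration tested (going by the name of the read-out)), compound 3 gives 54.1%, the second highest of the three numbers, and both of its neighbours lie within the scatter of it: a number 6 percentage points lower from compound 2 to compound 3 (within the scatter) and a number 7.6 percentage points higher from compound 1 to compound 3 (within the scatter). Compound 4 `CCCc1nc(-c2ccccc2)c(CNCCN2CCN(c3cccc(OC)c3)CC2)o1` differs from compound 3 by 3-methoxyphenyl in place of 4-fluorophenyl on an amine nitrogen in a ring. Among the compounds with values here, no measured step brings in a methoxy group. Within the data shown here, the only step beyond the scatter, a number 13.6 percentage points higher from compound 1 to compound 2 (beyond the scatter), exchanged one halogen for another, while the two moves of a fluoro-bearing aryl group stayed within the scatter. The change to compound 4 is therefore expected to give a step that stays within the scatter: a number 2.1 percentage points lower from compound 3 to compound 4 (within the scatter). Compound 4 is estimated at 52%, with a range from 32% to 72%.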

Compound 4, a percentage reported as inhibition, at one concentration (the size of the read-out at that concentration, not a potency): 40.2%
Compound 4: middle estimate off by 11.8 percentage points, on the high side, within the range that was stated.
By their numbers in this assay, from the lowest: compounds 4, 1, 3 and 2 (each within the scatter of the next, the first and the last beyond it).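

In this assay, the aryl group on the ring nitrogen now gives steps beyond the scatter with no halogen exchange: a number 13.9 percentage points lower from compound 3 to compound 4 (beyond the scatter) and a number 19.9 percentage points lower from compound 2 to compound 4 (beyond the scatter). The third step stays inside it, a number 6.3 percentage points lower from compound 1 to compound 4 (within the scatter), so 3-methoxyphenyl separates from 4-fluorophenyl and 2-chlorophenyl but not from 2-fluorophenyl. Nothing measured here explains these steps.

The compounds shown leave open whether the methoxy group or its place on the aryl ring governs the result. They also leave open how 4-methoxyphenyl or a pyridine ring on the same nitrogen would read.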